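Series notes: nitro for bromo on compound 1

The source may report more compounds than this note shows. Statements on the series, on what has been measured and on what is new or still open speak of the compounds shown alone.

Measured so far:
- compound 1, `CCOC(=O)C1=Cc2ccccc2OC1(OCc1cc(-c2ccc(Br)cc2)no1)C(F)(F)F`, in this series gives 52300 nM.
- compound 2, `O=C(O)C1=Cc2ccccc2OC1(OCc1cc(-c2ccc(F)cc2F)no1)C(F)(F)F`, gives only a limit of the assay, > 150000 nM.
- compound 3, `CCCCCCCCn1cc(COC2(C(F)(F)F)Oc3ccccc3C=C2C(=O)OCC)nn1`, likewise gives only a limit of the assay, > 150000 nM.

For the measured compounds named here, in a functional assay on HeLa cells (Homo sapiens) for inhibition, read by MTT assay, with a stated time of 24 h (a higher number here means a weaker inhibitor, a lower number a stronger inhibitor), compound 1 is the single compound with a resolved number, 52300 nM. Compound 2 returns a limit, > 150000 nM, and nothing more can be read from it. Compound 3 also returns a limit, > 150000 nM. Going by the values given here, both of these sit at the limit of > 150000 nM in this assay, at which 2 of the 3 values shown sit, so compound 1 stands alone as the one measurable inhibitor in the set, and no pair of measured compounds differs in a single place, so no measured step is available to anchor any change.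

Compound 4, `CCOC(=O)C1=Cc2ccccc2OC1(OCc1cc(-c2ccc([N+](=O)[O-])cc2)no1)C(F)(F)F`, is not yet measured. It differs from compound 1 by nitro in place of bromo on an aromatic carbon. Among the compounds with values here, with no measured step for a change of this kind, no direction beyond the scatter of this assay is expected; the step of a 1.1-fold higher number from compound 1 to compound 4 (0.06 log units; within the scatter) is estimated to stay within that scatter. Compound 4 is therefore expected near 60000 nM, with a plausible range from 20000 nM to 150000 nM, and a fair chance that only a limit is reported.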

Compound 4, half-maximal inhibitory concentration: > 150000 nM
Compound 4 was reported as a limit; the forecaster's own chance of this, stated with the estimate: 30%; middle value at least 2.5-fold (0.39 log units) away from the limit.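

The change from 4-bromophenyl to 4-nitrophenyl, on an aromatic carbon para to a large group, gives the series its first single-place step in this assay, with an at least 2.8-fold higher number from compound 1 to compound 4 (0.45 log units; beyond the scatter). This position is therefore not indifferent in this series: with the rest of compound 1 unchanged, replacing bromo with nitro is enough to lose the resolved number. As far as these compounds go, the value of compound 4 is a limit of the assay and not a number, so the true size of the step remains unknown and only its lower bound can be read: the limit of > 150000 nM in this assay, at which 3 of the 4 values shown sit.

Still open, from the compounds shown here alone, is whether the resolved number is particular to bromo, or whether chloro, methoxy or an amine at this position of the core of compound 1 would also give one in this assay. Also open, going by these compounds, is whether any group at this position can give a stronger inhibitor than compound 1, which stands at 52300 nM, or whether the resolved value of this compound is already the best this position offers.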